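Benzoxazole to benzothiazole in a cytotoxicity read-out

The source may hold more compounds than are shown below. What is called first, only, known or untested is meant among the compounds shown, and "the series" means these compounds.

Compound 1 `COc1ccc(-c2nc3ccccc3o2)cc1NC(=O)c1cc([N+](=O)[O-])ccc1Cl` gives > 25000 nM
Compound 2 `Cc1ccc(-c2nc3ccccc3s2)cc1NC(=O)c1cc([N+](=O)[O-])c(N2CCCCC2)cc1Cl` gives > 25000 nM
Compound 3 `COc1ccc(-c2nc3ccccc3s2)cc1NC(=O)c1cc([N+](=O)[O-])ccc1Cl` is not yet measured

In an ADME assay on HEK293 cells (Homo sapiens) for cytotoxicity, with a stated time of 72 h (on this read-out lower numbers stand for an effect already at smaller amounts and higher numbers for an effect only at larger amounts of compound), compound 1 gives > 25000 nM, which is a limit of the assay and not a number. Its standing is therefore shared, with the data showing (the limit of > 25000 nM in this assay, at which 2 of the 2 values shown sit).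

Compound 3 differs from compound 1 in one place, where 1,3-benzothiazol-2-yl stands in place of 1,3-benzoxazol-2-yl on an aromatic carbon (1,3-benzothiazol-2-yl in place of 1,3-benzoxazol-2-yl on an aromatic carbon). Among the measured compounds shown here, no measured pair shows this swap directly. Compound 2 also carries 1,3-benzothiazol-2-yl and gives > 25000 nM, which is likewise a limit. On that basis, no change beyond the scatter is expected in this assay, and another limit is likely. The expected step is a number no higher from compound 1 to compound 3 (the limit leaves the size open). For compound 3 the estimated value is 25000 nM, within an expected range of 12000 nM to 50000 nM.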

Compound 3, half-maximal effective concentration: > 25000 nM
Compound 3 ended at the assay's limit (the forecaster's own chance of this, stated with the estimate: 80%); the middle value lies on the limit itself.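

Compound 1 and compound 3 both end at a limit of the assay and not at a number, so no step between them can be read: the limit of > 25000 nM in this assay, at which 3 of the 3 values shown sit.

The compounds shown leave open whether 1,3-benzothiazol-2-yl in place of 1,3-benzoxazol-2-yl makes any difference in this assay, where none of them gives a true number.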